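The compounds below may be only part of what the source reports. "The series", "measured", "known", "first", "only" and "open" are said of these compounds alone.

Measured compounds in a functional assay on HCT-116 cells (Homo sapiens) for cytotoxicity, read by MTT assay, with a stated time of 48 h; a lower number here means a stronger inhibitor, a higher number a weaker inhibitor:
Compound 2 `COc1ccc(C(=O)/C=C/c2ccc3c(c2)B(O)OC3)cc1OC` gives 12200 nM.
Compound 3 `COc1cc(C(=O)/C=C/c2ccc3c(c2)B(O)OC3)cc(OC)c1OC` gives 7900 nM.
Compound 1 `O=C(/C=C/c1ccc2c(c1)B(O)OC2)c1ccc(O)c(O)c1` reaches only a limit of this assay, > 100000 nM.

Among these, compound 2 and compound 3 lie within the usual scatter of each other, the step of a 1.5-fold lower number from compound 2 to compound 3 (0.19 log units; within the scatter) being small; the limit of compound 1 the limit of > 100000 nM in this assay, at which 1 of the 3 values shown sits, stands apart as a limit and not a number. Compound 4 `COc1cc(C(=O)/C=C/c2ccc3c(c2)B(O)OC3)ccc1N` differs from compound 2 by amino in place of methoxy on an aromatic carbon. No measured step among these compounds replaces a methoxy with an amino; the only measured step, a 1.5-fold lower number from compound 2 to compound 3 (0.19 log units; within the scatter), adds a methoxy and stays within the scatter, so no change beyond the scatter is expected here either. Compound 4 is therefore estimated at 10000 nM, with a range from 3000 nM to 35000 nM, an expected step of a 1.2-fold lower number from compound 2 to compound 4 (0.09 log units; within the scatter).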

Compound 4, half-maximal inhibitory concentration: 27900 nM
Beside the measured number, compound 4's estimate is 2.8-fold (0.45 log units) below it; low and high end bracket the measured number.
By their numbers in this assay, from the lowest: compounds 3 and 2 (each within the scatter of the next); then compound 4. At a limit, above all of these: compound 1.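

Amino in place of methoxy, at this carbon ortho to a methoxy group and para to a large group, gives a 2.3-fold higher number from compound 2 to compound 4 (0.36 log units; beyond the scatter) in this assay and is the first single change here to go beyond the scatter. The number therefore does respond to what sits at this place, unlike a 1.5-fold lower number from compound 2 to compound 3 (0.19 log units; within the scatter) where the added methoxy stayed within the scatter. Nothing measured here accounts for the step.

Still open, from the compounds shown here alone, is whether the amino group itself or the missing methoxy sets the number. An ethoxy group, a fluorine or an acetamide at this carbon would help separate the two.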